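This account rests on a few compounds, and the source may have more. Where it says the series, first, only, none or still open, it means among the compounds named here.

Measured so far in a functional assay on MDA-MB-231 cells (Homo sapiens) for inhibition, read by MTT assay, with a stated time of 48 h; on this read-out lower numbers stand for stronger inhibition and higher numbers for weaker inhibition:
- compound 1 `COc1cc(-c2cc(/C=C/C(=O)c3ccc(Cl)c(Cl)c3)[nH]n2)cc(OC)c1OC`: 2100 nM
- compound 2 `COc1cc(-c2cc(/C=C/C(C)=O)[nH]n2)cc(OC)c1OC`: 27300 nM

Compound 2 stands at the highest of the two numbers in this assay, its nearest neighbour being compound 1. Compound 3 `COc1cc(-c2cc(/C=C/C(=O)c3ccc(F)c(F)c3)[nH]n2)cc(OC)c1OC` is the next member; the change is 3,4-difluorophenyl in place of methyl on a carbonyl carbon. Among the measured compounds shown here, the only measured step that bears on this exchange is the reverse one, a 13-fold higher number from compound 1 to compound 2 (1.11 log units; beyond the scatter), which was large and beyond the scatter. Restoring a halogenated aryl ring on the carbonyl carbon is therefore expected to give a large step down, estimated as a 9.1-fold lower number from compound 2 to compound 3 (0.96 log units; beyond the scatter). Compound 3 is accordingly expected near 3000 nM, with a range of 1200 nM to 8000 nM.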

Compound 3, half-maximal inhibitory concentration: 1500 nM
Beside the measured number, compound 3's estimate is 2.0-fold (0.30 log units) above it; measured number inside the range.
By their numbers in this assay, from the lowest: compounds 3 and 1 (each within the scatter of the next); then compound 2.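

In this assay, 3,4-difluorophenyl on the carbonyl carbon confirms the large aryl-over-methyl gap, with an 18-fold lower number from compound 2 to compound 3 (1.26 log units; beyond the scatter) as the step. Fluorine and chlorine on the ring cannot be told apart here, with a 1.4-fold lower number from compound 1 to compound 3 (0.15 log units; within the scatter) as the step, so the identity of these two halogens makes no readable difference at this position. No evidence bears on the reason for the gap.

Open, from the compounds shown here alone, is whether unsubstituted phenyl or an aminophenyl group on the carbonyl carbon would match compound 1 and compound 3 or move toward compound 2. Also open, going by these compounds, is how a longer alkyl chain in place of methyl would read.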